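The source may hold more compounds than are shown below. What is called first, only, known or untested is meant among the compounds shown, and "the series" means these compounds.

Among the measured compounds shown here, in a functional assay on MDA-MB-231 cells (Homo sapiens) for antiproliferative activity, read by MTT assay (on this read-out lower numbers stand for stronger inhibition and higher numbers for weaker inhibition), compound 3 `CCCCCCCCCCCC1(O)CC(=O)c2c(O)cc(O)cc2O1` gives 42800 nM, the higher of the two exact numbers so far. Compound 1 `CCCCC/C=C\C/C=C\CCCCCCCC1(O)CC(=O)c2c(O)cc(OCOC)cc2O1` gives 16100 nM, lower than compound 3 by more than the scatter. Compound 2 `CCCCCCCCCCCCCCCCCCCC1(O)CC(=O)c2c(O)cc(O)cc2O1` reads > 87000 nM, which is a limit of the assay and not a number.

The next step leads to compound 4 `CCCCC/C=C\C/C=C\CCCCCCCC1(O)CC(=O)c2c(O)cc(O)cc2O1` and is deca-1,4-dien-1-yl in place of butyl on a saturated chain carbon, seven bonds along the chain from a saturated ring carbon.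

For the measured compounds named here, only one measured step changes the chain alone: an at least 2.0-fold lower number from compound 2 to compound 3 (0.30 log units; that floor lies within the scatter). Its floor lies within the scatter, so it fixes no size, and it concerns a saturated chain. Compound 1 carries the same deca-1,4-dien-1-yl chain end at 16100 nM, but its core differs from that of compound 4.

No step beyond the scatter is therefore expected in this assay. The expected change is a 1.2-fold lower number from compound 3 to compound 4 (0.09 log units; within the scatter). For compound 4 the estimated value is 35000 nM, with an expected range from 13000 nM to 85000 nM.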

Compound 4, half-maximal inhibitory concentration: 6790 nM
Compound 4: middle estimate off by 5.2-fold (0.71 log units), on the high side, outside the stated range (below it).
By their numbers in this assay, from the lowest: compound 4; then compound 1; then compound 3. At a limit, above all of these: compound 2.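

In this assay, among the compounds shown here, this chain position gives the first step that is clearly beyond the scatter: a 6.3-fold lower number from compound 3 to compound 4 (0.80 log units; beyond the scatter), with deca-1,4-dien-1-yl in place of butyl on a saturated chain carbon, seven bonds along the chain from a saturated ring carbon. With that chain held constant, the oxygen on the aromatic ring can also be read: a 2.4-fold lower number from compound 1 to compound 4 (0.37 log units; beyond the scatter), with hydrogen in place of methoxymethyl. No measurement shown gives a cause for either step.

As far as these compounds go, compound 4 changes chain length and adds the two double bonds in the same step, so the contribution of each remains open. A saturated chain of the same length as in compound 4 would separate the two, and a carboxylic acid at the chain end would test whether that end tolerates change.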